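Adding 4-acetylphenyl to compound 3: working notes

This account rests on a few compounds, and the source may have more. Where it says the series, first, only, none or still open, it means among the compounds named here.

Measured in a functional assay on MDA-MB-231 cells (Homo sapiens) for antiproliferative activity, read by MTT assay, with a stated time of 72 h; a lower number here means a stronger inhibitor, a higher number a weaker inhibitor:
- compound 1 `CC(=O)c1ccc(-c2cccc(NC(=O)CCc3ccc4c(c3)COB4O)c2)cc1`: 66000 nM
- compound 2 `CC(=O)c1ccc(-c2cccc(NC(=O)CCc3ccccc3)c2)cc1`: 2700 nM
- compound 3 `O=C(CCc1cccc2c1C(O)OC2)Nc1ccccc1`: 12000 nM

Compound 3 sits in the middle of the three values, with a higher number than compound 2 and a lower number than compound 1. Compound 4 `CC(=O)c1ccc(-c2cccc(NC(=O)CCc3cccc4c3C(O)OC4)c2)cc1` differs from compound 3 by one change: 4-acetylphenyl in place of hydrogen on an aromatic carbon. This is 4-acetylphenyl in place of hydrogen on an aromatic carbon, meta to a large group.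

For the measured compounds named here, no measured pair isolates this change. The nearest evidence is a 24-fold lower number from compound 1 to compound 2 (1.39 log units; beyond the scatter), a large step between two compounds that both carry 4-acetylphenyl. Their values fall on either side of compound 3, so neither direction is favoured, and the range stays wide. The expected step in this assay is a 1.2-fold lower number from compound 3 to compound 4 (0.08 log units; within the scatter), with none expected beyond the scatter. For compound 4 the estimated value is 10000 nM, with an estimated range of 2500 nM to 45000 nM.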

Compound 4, half-maximal inhibitory concentration: 29000 nM
For compound 4 the middle estimate is 2.9-fold (0.46 log units) below the measured one, within the range that was stated.
By their numbers in this assay, from the lowest: compound 2; then compound 3; then compound 4; then compound 1.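

In this assay, 4-acetylphenyl in place of hydrogen on this aromatic carbon now has a direct reading, a 2.4-fold higher number from compound 3 to compound 4 (0.38 log units; beyond the scatter), and the change does not lower the number on this core. With 4-acetylphenyl present in all three compounds, the group on the saturated chain carbon still moves the value, giving an 11-fold higher number from compound 2 to compound 4 (1.03 log units; beyond the scatter) and a 2.3-fold lower number from compound 1 to compound 4 (0.36 log units; beyond the scatter). Nothing measured gives a cause for these steps.

Going by these compounds, whether a carboxylic acid or an amine in place of the acetyl of 4-acetylphenyl would keep this direction stays open. So does the size of the same change on the other cores.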